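The compounds below may be only part of what the source reports. "The series", "measured", "known", "first", "only" and "open" are said of these compounds alone.

Measured in a functional assay on RAW264.7 cells (Mus musculus) for inhibition, read by Griess assay, with stated times of 3 h and 24 h; on this read-out higher numbers stand for weaker inhibition and lower numbers for stronger inhibition:
- compound 1 `C=C1CCC2[C@](C)(CO)[C@H](O)CC[C@@]2(C)[C@@H]1CCn1ccc(=O)[nH]c1=O`: > 100000 nM (a limit)
- compound 2 `C=C1CCC2[C@](C)(CO)[C@H](O)CC[C@@]2(C)[C@@H]1CCn1ccnc1`: > 50000 nM (a limit)
- compound 3 `C=C1CCC2[C@](C)(CO)[C@H](O)CC[C@@]2(C)[C@@H]1CCOc1ccc(Oc2ccccc2)cc1`: 12800 nM

Compound 1 stands only at a limit, > 100000 nM, so any step from it lacks an exact starting point. Compound 4 `C=C1CCC2[C@](C)(CO)[C@H](O)CC[C@@]2(C)[C@@H]1CCOC(=O)c1ccccc1` keeps the shared core and changes the group on the chain: a group of 9 heavy atoms (7 carbon, 2 oxygen; one six-membered aromatic ring of carbon only) in place of a group of 8 heavy atoms (4 carbon, 2 nitrogen, 2 oxygen; one six-membered aromatic ring with 2 hetero atoms), on a saturated chain carbon, two bonds along the chain from a saturated ring carbon. Benzoyloxy enters on a saturated chain carbon, two bonds along the chain from a saturated ring carbon, with one six-membered aromatic ring of carbon only in place of a ring with 2 hetero atoms.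

Among the compounds with values here, the one measured step at this place is a step that the two limits leave unreadable from compound 1 to compound 2, and it offers no size to carry over. Within the data shown here, the nearest guide is compound 3, which also carries carbon-only aromatic rings on the chain and gives the sole numerical value, 12800 nM. Stronger inhibition in this assay is therefore expected, though the size is only loosely fixed. The expected step is an at least 4.0-fold lower number from compound 1 to compound 4 (0.60 log units; beyond the scatter).

For compound 4 the estimated value is 25000 nM, with an expected range from 7000 nM to 90000 nM.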

Compound 4, half-maximal inhibitory concentration: > 100000 nM
Compound 4: no number, only a limit (the forecaster's own chance of this, stated with the estimate: 30%); middle value at least 4.0-fold (0.60 log units) from the limit.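

Compound 4 gives only a limit (> 100000 nM), and compound 1 and compound 2 also stand at limits, so the steps from compound 1 and from compound 2 to compound 4 cannot be read. The compounds shown leave open whether benzoyloxy, 1H-imidazol-1-yl and the group of compound 1 differ at all in strength of inhibition.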